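The compounds below may be only part of what the source reports. "The series", "measured", "known", "first", "only" and "open" are said of these compounds alone.

Measured in an ADME assay on J774 cells (Mus musculus) for cytotoxicity, read by resazurin assay, with a stated time of 72 h; on this read-out higher numbers stand for lower toxicity in this test and lower numbers for higher toxicity in this test:
- compound 1 `C/C(=N\Nc1nc(-c2ccc(Cl)cc2Cl)cs1)c1ccc(Cl)c(Cl)c1`: > 50000 nM
- compound 2 `C/C(=N\Nc1nc(-c2ccc(Cl)c(Cl)c2)cs1)c1ccc(Cl)c(Cl)c1`: > 50000 nM

Compound 2 gives > 50000 nM, which is a limit and not a number. Compound 3 `C/C(=N\Nc1nc(-c2ccc(Cl)c(Cl)c2Cl)cs1)c1ccc(Cl)c(Cl)c1` differs from compound 2 by chloro in place of hydrogen on an aromatic carbon. Going by the values given here, the only measured step bearing on this change is a step that the two limits leave unreadable from compound 1 to compound 2. It offers no size to carry over, and the sole reference point is the limit of > 50000 nM in this assay, at which 2 of the 2 values shown sit. The estimated step is a number no higher from compound 2 to compound 3 (the limit leaves the size open), with no change beyond the scatter expected in this assay, and a further limit is the likeliest report. For compound 3 the expected value is 50000 nM, with an estimated range of 20000 nM to 100000 nM.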

Compound 3, half-maximal cytotoxic concentration: 21300 nM
For compound 3 the middle estimate is 2.3-fold (0.37 log units) above the measured one; the range from low to high includes it.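

In this assay, going by these compounds alone, chloro on this aromatic carbon, ortho to a chloro group and ortho to a large group, gives the first readable change: an at least 2.3-fold lower number from compound 2 to compound 3 (0.37 log units; beyond the scatter), and likewise an at least 2.3-fold lower number from compound 1 to compound 3 (0.37 log units; beyond the scatter). The step between compound 1 and compound 2 cannot be read. Both readable steps are minimum sizes only, and the true sizes stay open: the limit of > 50000 nM in this assay, at which 2 of the 3 values shown sit.

As far as these compounds go, whether this drop is specific to chloro or would follow any group on this carbon remains open. A methyl, a methoxy or an amine at this position would separate the two readings.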